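A few compounds are considered here, and "the series" means these few. Any claim that something is new, unique, unknown or untested is made for them only; others in the source may bear on it.

Of the compounds shown here, three of a shared core have been measured in a functional assay on A-375 cells (Homo sapiens) for antiproliferative activity, read by trypan blue exclusion, with a stated time of 48 h, tested at 5 uM; on this read-out higher numbers stand for a weaker effect at the one concentration tested and lower numbers for a stronger effect. Compound 1 `CCCCC#Cc1ccc(S(=O)(=O)Nc2cccc(-c3csc(NC(C)=O)n3)c2)cc1` gives 9.3%, compound 2 `C#Cc1ccc(S(=O)(=O)Nc2cccc(-c3csc(NC(C)=O)n3)c2)cc1` gives 38.3%, and compound 3 `CCCCCC/C=C\c1ccc(S(=O)(=O)Nc2cccc(-c3csc(NC(C)=O)n3)c2)cc1` gives 2.3%. Compound 3 has the lowest of the three numbers; its nearest neighbour is compound 1, with a gap that lies within the scatter, while compound 2 sits well apart from it beyond the scatter.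

Compound 4 `CCCCCCCCc1ccc(S(=O)(=O)Nc2cccc(-c3csc(NC(C)=O)n3)c2)cc1` is the next member. Its change from compound 3 is a group of 8 heavy atoms (8 carbon; no ring) in place of a group of 8 heavy atoms (8 carbon; no ring), on an aromatic carbon: the group that leaves carries one double bond outside aromatic rings, the octyl that enters carries none, and the place is on an aromatic carbon of a six-membered aromatic ring of carbon only, para to a large group.

For the measured compounds named here, the steps that bear on this one all alter the same chain. The step of a number 29 percentage points higher from compound 1 to compound 2 (beyond the scatter) was modest, the step of a number 36 percentage points lower from compound 2 to compound 3 (beyond the scatter) was large, and the step of a number 7 percentage points lower from compound 1 to compound 3 (within the scatter) stayed within the scatter. Exchanging one chain of eight carbons for another of the same length is the smallest of these alterations, so no step beyond the scatter is expected in this assay. Compound 4 is therefore estimated at 5%, between 1% and 15%, an expected step of a number 2.7 percentage points higher from compound 3 to compound 4 (within the scatter).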

Compound 4, a percentage reported as activity, at one concentration (the size of the read-out at that concentration, not a potency): < 1%
Compound 4 was reported as a limit; the forecaster's own chance of this, stated with the estimate: 0%; middle value at least 4 percentage points away from the limit.
By their numbers in this assay, from the lowest: compounds 3 and 1 (each within the scatter of the next); then compound 2. At a limit, below all of these: compound 4.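

In this assay compound 4 gives < 1%, which is a limit of the assay and not a number: the limit of < 1% in this assay, at which 1 of the 4 values shown sits. Octyl in place of the unsaturated chain gives a number at least 1.3 percentage points lower from compound 3 to compound 4 (that floor lies within the scatter), so at this place on the six-membered aromatic ring, para to a large group, a chain with no double bond outside aromatic rings still keeps the read-out low, which the earlier compounds, all with an unsaturated chain, could not show. Octyl in place of hex-1-yn-1-yl gives a number at least 8.3 percentage points lower from compound 1 to compound 4 (that floor lies within the scatter), while octyl in place of ethynyl gives a number at least 37.3 percentage points lower from compound 2 to compound 4 (beyond the scatter), so among the chains shown the ethynyl group alone stands apart, and the triple bond itself is not what separates it from the rest.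

On these data alone, with compound 4 at a limit, how far it really lies from compound 1 and compound 3 stays unknown. The compounds shown also leave open whether a longer chain such as decyl, or an octyl chain ending in an amine or a carboxylic acid, would keep the read-out this low at the same place.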